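The compounds below may be only part of what the source reports. "The series", "measured", "known", "first", "only" and "open" are said of these compounds alone.

Compound 3 `Cc1nc(S(C)(=O)=O)ccc1Oc1ncnc(OC2CCN(C(=O)O[C@H](C)C(F)(F)F)CC2)c1F` gives the lowest number of the three measured compounds in a functional assay on isolated protein for inhibition of Glucose-dependent insulinotropic receptor (Homo sapiens), read by HTRF and cAMP accumulation (on this read-out higher numbers stand for an effect only at larger amounts of compound and lower numbers for an effect already at smaller amounts), namely 9.2 nM. Its neighbours are compound 1 `Cc1nc(S(C)(=O)=O)ccc1Oc1ncnc(OC2CCN(C(=O)OC(C)C)CC2)c1F`, which in this assay gives 21 nM, and compound 2 `Cc1nc(S(C)(=O)=O)ccc1Oc1ncnc(OC2CCN(C(=O)O[C@@H](C)CF)CC2)c1F`, which in this assay gives 186 nM. Compound 4 `Cc1nc(S(C)(=O)=O)ccc1Oc1ncnc(OC2CCN(C(=O)OC3COC3)CC2)c1F` carries oxetan-3-yl in place of 1-(trifluoromethyl)ethyl on an oxygen next to a carbonyl group. The measured steps at this same oxygen are a 2.3-fold lower number from compound 1 to compound 3 (0.36 log units; beyond the scatter) and a 20-fold lower number from compound 2 to compound 3 (1.31 log units; beyond the scatter), so changes of the ester group at this oxygen have moved the number in both directions and by up to a large amount. Going by the values given here, none of the measured compounds carries a ring at this position, and no step shows what a ring here does. Because the two recorded steps a 2.3-fold lower number from compound 1 to compound 3 (0.36 log units; beyond the scatter) and a 20-fold lower number from compound 2 to compound 3 (1.31 log units; beyond the scatter) both run toward compound 3 as the lowest number, compound 4 is expected to give a higher number, with a modest step of a 6.5-fold higher number from compound 3 to compound 4 (0.81 log units; beyond the scatter). Compound 4 is therefore estimated at 60 nM in this assay, within a range from 15 nM to 300 nM.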

Compound 4, half-maximal effective concentration: 326 nM
Compound 4: middle estimate off by 5.4-fold (0.74 log units), on the low side; measured number outside the range, above it.
By their numbers in this assay, from the lowest: compound 3; then compound 1; then compounds 2 and 4 (each within the scatter of the next).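

The first ring at this oxygen, oxetan-3-yl, brings a large move in this assay, with a 35-fold higher number from compound 3 to compound 4 (1.55 log units; beyond the scatter) and a 16-fold higher number from compound 1 to compound 4 (1.19 log units; beyond the scatter), so a group with one four-membered ring does not hold the low numbers of the open-chain isopropyl and 1-(trifluoromethyl)ethyl groups. Against the 1-(fluoromethyl)ethyl group the change gives a 1.8-fold higher number from compound 2 to compound 4 (0.24 log units; within the scatter), so compounds 2 and 4 cannot be told apart, and the ring group and this singly fluorinated chain share the high end of the series. Nothing available gives a reason for these steps.

The compounds shown leave open whether the ring itself or its oxygen goes with the higher number, which a cyclobutyl group at the same oxygen would help to separate. They also leave open how a larger ring, such as tetrahydrofuran-3-yl, would read here.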